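Swapping the aryl group on the saturated ring carbon

This account rests on a few compounds, and the source may have more. Where it says the series, first, only, none or still open, it means among the compounds named here.

Of the compounds shown here, two of a shared core have been measured in a functional assay on Hs-578T cells (Homo sapiens) for antiproliferative activity, with a stated time of 48 h (on this read-out lower numbers stand for stronger inhibition of growth and higher numbers for weaker inhibition of growth), so far. Compound 1 `Cc1cc(O)c(C2=NN(c3ccc(S(N)(=O)=O)cc3)C(c3ccccc3O)C2)cc1Cl` gives 4640 nM in this assay, and compound 2 `Cc1cc(O)c(C2=NN(c3ccc(S(N)(=O)=O)cc3)C(c3ccccc3Cl)C2)cc1Cl` gives 3280 nM. Compound 2 carries the lowest of the two numbers, but the step of a 1.4-fold lower number from compound 1 to compound 2 (0.15 log units; within the scatter) leaves the two within the scatter, so no order between them can be claimed.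

Compound 3 `COc1ccc(C2CC(c3cc(Cl)c(C)cc3O)=NN2c2ccc(S(N)(=O)=O)cc2)cc1OC` differs from compound 2 by 3,4-dimethoxyphenyl in place of 2-chlorophenyl on a saturated ring carbon. Going by the values given here, the only measured step at that same saturated ring carbon, from compound 1 to compound 2, exchanged hydroxy for chloro on the aromatic carbon and stayed within the scatter. Nothing measured bears on the entry of two methoxy groups, so no step beyond the scatter is expected in this assay. The expected step of a 1.1-fold higher number from compound 2 to compound 3 (0.03 log units; within the scatter) is accordingly small. Compound 3 is estimated at 3500 nM, with a range from 1500 nM to 8500 nM.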

Compound 3, concentration for 50% growth inhibition: 3290 nM
Beside the measured number, compound 3's estimate is 1.1-fold (0.03 log units) above it; measured number inside the range.
By their numbers in this assay, from the lowest: compounds 2, 3 and 1 (each within the scatter of the next).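

In this assay the exchange of 2-chlorophenyl for 3,4-dimethoxyphenyl on the saturated ring carbon gives a 1.0-fold higher number from compound 2 to compound 3 (0.00 log units; within the scatter) and the exchange of 2-hydroxyphenyl for the same group gives a 1.4-fold lower number from compound 1 to compound 3 (0.15 log units; within the scatter). Until now this position had shown only one substituent traded on the same phenyl ring, whereas here a group with more heavy atoms and two hydrogen-bond acceptors enters with no step beyond the scatter. No measurement at hand accounts for how close the three numbers lie.

From the compounds shown here alone, all three compounds carry a six-membered aromatic ring of carbon at this position, so it remains open whether a cyclohexyl group or a plain alkyl chain would keep the number within the scatter. Equally open, going by these compounds, is whether a carboxylic acid or an amine on the phenyl ring would move it beyond the scatter.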